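Adding a Second Fluoro to a Fused Ring

This account rests on a few compounds, and the source may have more. Where it says the series, first, only, none or still open, it means among the compounds named here.

Compound 1, `N#Cc1ccc(Nc2nccc(Nc3ccc4cc(C#N)ccc4c3F)n2)cc1`, was tested in an ADME assay on MT2 cells (Homo sapiens) for inhibition, read by MTT assay (on this read-out higher numbers stand for lower toxicity in this test and lower numbers for higher toxicity in this test), and gave 45000 nM. Among the compounds for which a plain number is known, compound 1 has the highest value; compound 2, `Cc1cc2cc(C#N)ccc2c(C)c1Nc1ncnc(Nc2ccc(C#N)cc2)n1`, gives 9500 nM. Compound 3, `N#Cc1ccc(Nc2nccc(Nc3ccc4cc(C#N)ccc4c3)n2)cc1`, reached only the limit of this assay, > 100000 nM, and so no number is known for it. For the measured compounds named here, the one step between measured compounds that differ in a single place runs an at least 2.2-fold higher number from compound 1 to compound 3 (0.34 log units; beyond the scatter), where the limit of > 100000 nM in this assay, at which 1 of the 3 values shown sits, sets a floor on its size.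

Compound 4, `N#Cc1ccc(Nc2nccc(Nc3c(F)cc4cc(C#N)ccc4c3F)n2)cc1`, differs from compound 1 by fluoro in place of hydrogen on an aromatic carbon, on an aromatic carbon of a six-membered aromatic ring of carbon only, part of a fused system of two rings, meta to a fluoro group. This change runs opposite to the step from compound 1 to compound 3, in which removing a fluoro gave a higher number; a second fluoro is therefore expected to push the number modestly lower. The estimated step is a 1.6-fold lower number from compound 1 to compound 4 (0.21 log units; within the scatter), giving an expected value for compound 4 of 28000 nM, in the range 11000 nM to 70000 nM.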

Compound 4, half-maximal cytotoxic concentration: 4800 nM
For compound 4 the middle estimate is 5.8-fold (0.77 log units) above the measured one; measured number outside the range, below it.
By their numbers in this assay, from the lowest: compounds 4 and 2 (each within the scatter of the next); then compound 1. At a limit, above all of these: compound 3.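

In this assay the added fluoro gives a 9.4-fold lower number from compound 1 to compound 4 (0.97 log units; beyond the scatter) and so, on this read-out, points to higher toxicity in this test. The position ortho to a large group and meta to a fluoro group is therefore not indifferent to this small change, whereas the earlier fluoro step could be sized only against a limit and concerned a different place on the ring. Nothing shown offers a measured reason for the drop.

From the compounds shown here alone, it remains open whether the drop belongs to fluoro itself or would also follow with a chloro, a methyl or a methoxy group, or an amine, at this position. Going by these compounds, it is equally open whether a fluoro here would lower the number on its own, with no other fluoro on the ring.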